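A few compounds are considered here, and "the series" means these few. Any claim that something is new, unique, unknown or untested is made for them only; others in the source may bear on it.

Compound 1 `Cc1ccc(S(=O)(=O)n2cc(COC3=C/C(=N\c4ccccc4)c4ccccc4C3=O)nn2)cc1`: 6710 nM
Compound 2 `CC(=O)c1ccc(/N=C2\C=C(OCc3cn(S(=O)(=O)c4ccc(C)cc4)nn3)C(=O)c3ccccc32)cc1`: 5300 nM
Compound 3 `COc1ccc(/N=C2\C=C(OCc3cn(S(=O)(=O)c4ccc(C)cc4)nn3)C(=O)c3ccccc32)cc1`: 6960 nM

In a functional assay on HL-60 cells (Homo sapiens) for cytotoxicity, read by MTT assay, with a stated time of 72 h (on this read-out lower numbers stand for stronger inhibition and higher numbers for weaker inhibition), compound 1 gives 6710 nM, which lies within the scatter of both other compounds: a 1.3-fold lower number from compound 1 to compound 2 (0.10 log units; within the scatter) and a 1.0-fold higher number from compound 1 to compound 3 (0.02 log units; within the scatter). Compound 4 `Cc1ccc(S(=O)(=O)n2cc(COC3=C/C(=N\c4ccc(Cl)cc4)c4ccccc4C3=O)nn2)cc1` is not yet measured in this assay. It differs from compound 1 by chloro in place of hydrogen on an aromatic carbon. The three measured steps all vary the same position on the same aromatic ring, and none left the scatter: a 1.3-fold lower number from compound 1 to compound 2 (0.10 log units; within the scatter), a 1.0-fold higher number from compound 1 to compound 3 (0.02 log units; within the scatter) and a 1.3-fold higher number from compound 2 to compound 3 (0.12 log units; within the scatter). On this basis no step beyond the scatter is expected in this assay from compound 1 to compound 4, in either direction. Compound 4 is therefore estimated to give about 6500 nM, with a likely range from 3300 nM to 13000 nM. The expected step is a 1.0-fold lower number from compound 1 to compound 4 (0.01 log units; within the scatter).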

Compound 4, half-maximal inhibitory concentration: 6920 nM
For compound 4 the middle estimate is 1.1-fold (0.03 log units) below the measured one; the measured number falls inside the stated range.
By their numbers in this assay, from the lowest: compounds 2, 1, 4 and 3 (each within the scatter of the next).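

Chloro is the first halogen at this position, and in this assay it too stays within the scatter of the other compounds (first a 1.0-fold higher number from compound 1 to compound 4 (0.01 log units; within the scatter); then a 1.0-fold lower number from compound 3 to compound 4 (0.00 log units; within the scatter); and last a 1.3-fold higher number from compound 2 to compound 4 (0.12 log units; within the scatter)). Hydrogen, acetyl, methoxy and chloro on this aromatic carbon thus all give values within the scatter of one another, so the flat picture now also covers a halogen. No measured evidence bears on why this position responds so little. From the compounds shown here alone, whether an amine or a carboxylic acid here would leave the scatter remains open. So does whether a change elsewhere on the shared core would move the number.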